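Swapping a Nitrile for Methoxy: What to Expect

The source may hold more compounds than are shown below. What is called first, only, known or untested is meant among the compounds shown, and "the series" means these compounds.

Of the compounds shown here, two have been tested in a functional assay on HO8910 cells (Homo sapiens) for cytotoxicity, read by CCK-8 assay, with a stated time of 24 h; a higher number here means a weaker inhibitor, a lower number a stronger inhibitor. Compound 1 `C/C(=C\c1ccc(-c2ccc(F)cc2)o1)C(N)=O` gives 990 nM. Compound 2 `C/C(=C\c1cc(-c2ccc(C#N)cc2)cs1)C(N)=O` gives 130 nM, the lower of the two numbers, with compound 1 standing beyond the scatter above it. Compound 3 `COc1ccc(-c2csc(/C=C(\C)C(N)=O)c2)cc1` is the next to be measured. It differs from compound 2 in one place: methoxy in place of cyano on an aromatic carbon. No single-change comparison is available to guide this swap. The expected change is therefore small, a 1.9-fold higher number from compound 2 to compound 3 (0.28 log units; within the scatter), a slight rise that may stay within the scatter. On this basis compound 3 is estimated at 250 nM, within a range of 80 nM to 900 nM.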

Compound 3, half-maximal inhibitory concentration: > 50000 nM
Compound 3: a limit, no number (the forecaster's own chance of this, stated with the estimate: 3%); middle value at least 200-fold (2.30 log units) away from the limit.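

In this assay, the group at this place on the aromatic ring matters far more than the counts suggest: cyano and methoxy match in heavy atoms and hydrogen-bond acceptors, yet methoxy in place of cyano gives an at least 380-fold higher number from compound 2 to compound 3 (2.58 log units; beyond the scatter). So, in this one pair, the two groups are not interchangeable. The reading for compound 3 is a limit, not a number: the limit of > 50000 nM in this assay, at which 1 of the 3 values shown sits.

The data do not explain why the swap has so large an effect. Going by these compounds, whether an amine or a carboxylic acid on this carbon would behave like cyano or like methoxy also stays open.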